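Notes on the five-membered aryl replacement series

The source may report more compounds than this note shows. Statements on the series, on what has been measured and on what is new or still open speak of the compounds shown alone.

Measured so far:
compound 1, `Cc1ccccc1-c1sc(N)c(C(=O)c2ccc(Cl)cc2)c1CC(C)(C)C`, giving 1%
compound 2, `Cc1noc(C)c1-c1sc(N)c(C(=O)c2ccc(Cl)cc2)c1CC(C)(C)C`, giving 1%

In an assay on CHO cells for displacement of a labelled ligand from adenosine receptor A3 (Homo sapiens), read by scintillation counting, tested at 10 uM (a higher number here means more inhibition at the concentration tested (going by the name of the read-out), a lower number less inhibition), compound 2 gives 1%, level with compound 1 at the digits reported, and the step of no change at the digits printed from compound 1 to compound 2 (within the scatter) lies within the scatter. Compound 3 is `CC(C)(C)Cc1c(-c2cccs2)sc(N)c1C(=O)c1ccc(Cl)cc1`. It differs from compound 2 as follows: thiophen-2-yl in place of 3,5-dimethyl-1,2-oxazol-4-yl on an aromatic carbon. Among the compounds with values here, the only step that bears on this change is no change at the digits printed from compound 1 to compound 2 (within the scatter), which showed nothing beyond the scatter, so no shift beyond the scatter is expected in this assay here either. Compound 3 is therefore expected to give 2%, within the range 0% to 12%, which means an expected step of a number 1 percentage points higher from compound 2 to compound 3 (within the scatter).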

Compound 3, a percentage reported as inhibition, at one concentration (the size of the read-out at that concentration, not a potency): 1%
The estimate for compound 3 lay 1 percentage points above the measured number; the measured number falls inside the stated range.
By their numbers in this assay, from the lowest: compounds 1, 2 and 3 (each within the scatter of the next).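

In this assay, thiophen-2-yl in place of 3,5-dimethyl-1,2-oxazol-4-yl gives no change at the digits printed from compound 2 to compound 3 (within the scatter) at this carbon next to the ring sulfur, and thiophen-2-yl in place of 2-methylphenyl gives no change at the digits printed from compound 1 to compound 3 (within the scatter) at the same carbon. A five-membered aromatic ring with 1 sulfur therefore joins the two earlier groups, and the three groups at this position are not told apart by this read-out. Nothing measured here bears on the reason for this result.

On these data alone, whether an amine or a carboxylic acid on this carbon would move the number stays open. Also open, as far as these compounds go, is whether a longer chain in place of the neopentyl group would do so.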